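A few compounds are considered here, and "the series" means these few. Any claim that something is new, unique, unknown or untested is made for them only; others in the source may bear on it.

Measured so far:
- compound 1 `CCOC(=O)/C(O)=C/C(=O)c1cn(Cc2cc(F)c(F)c(F)c2)c2cccc(OC)c12`: 33400 nM
- compound 2 `CCOC(=O)/C(O)=C/C(=O)c1cn(Cc2ccc(F)c(F)c2F)c2cccc(OC)c12`: 42700 nM

In an ADME assay on MT4 cells (Homo sapiens) for cytotoxicity, read by MTT assay (a higher number here means that more compound is tolerated, a lower number that less compound is tolerated), compound 2 holds the highest of the two numbers, with compound 1 the nearest; the step of a 1.3-fold higher number from compound 1 to compound 2 (0.11 log units; within the scatter) is within the scatter, so the two are not separated. Compound 3 `CCOC(=O)/C(O)=C/C(=O)c1cn(Cc2ccccc2F)c2cccc(OC)c12` is the next member. The change from compound 2 is 2-fluorophenyl in place of 2,3,4-trifluorophenyl on a saturated chain carbon bound to an aromatic nitrogen, that is, two of the three fluorines on the benzyl ring are removed. Going by the values given here, the only measured step that bears on this is the rearrangement of the same three fluorines, a 1.3-fold higher number from compound 1 to compound 2 (0.11 log units; within the scatter), which stayed within the scatter. On that basis no step beyond the scatter is expected for compound 3 in this assay, and the estimated step is a 1.1-fold lower number from compound 2 to compound 3 (0.03 log units; within the scatter). The expected value for compound 3 is 40000 nM, with a range from 15000 nM to 110000 nM.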

Compound 3, half-maximal cytotoxic concentration: 63300 nM
Estimate against measurement, compound 3: 1.6-fold (0.20 log units) below; measured number inside the range.
By their numbers in this assay, from the lowest: compounds 1, 2 and 3 (each within the scatter of the next).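

At the saturated chain carbon bound to an aromatic nitrogen, the earlier pair compared only two trifluorophenyl arrangements. Compound 3 extends the comparison to 2-fluorophenyl, and in this assay this group is not separated from 2,3,4-trifluorophenyl (a 1.5-fold higher number from compound 2 to compound 3 (0.17 log units; within the scatter)) or from 3,4,5-trifluorophenyl (a 1.9-fold higher number from compound 1 to compound 3 (0.28 log units; within the scatter)). Across these compounds, neither the number of fluorines nor their arrangement on the ring is shown to matter in this assay, and no available measurement speaks to why.

Open, on these data alone, is whether this tolerance extends to groups other than fluorophenyl at this place, such as unsubstituted phenyl, an aminophenyl or a longer chain to the ring. Also open, as far as these compounds go, is whether the same holds when the ethyl ester of the shared core is replaced by a carboxylic acid.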